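This account rests on a few compounds, and the source may have more. Where it says the series, first, only, none or still open, it means among the compounds named here.

Compound 1 `Nc1nc2ccccn2c1-c1ccc(O)cc1` stands at the edge of what an assay on isolated protein for inhibition of ubiquitin carboxyl-terminal hydrolase 14 (Homo sapiens) (on this read-out higher numbers stand for weaker inhibition and lower numbers for stronger inhibition), can report: in this assay compound 1 gives > 100000 nM, which is a limit of the assay and not a number. Compound 2 `Nc1nc2cc(C(F)(F)F)ccn2c1-c1ccc(O)cc1`, which carries trifluoromethyl in place of hydrogen on an aromatic carbon of the shared core, gives > 100000 nM in this assay, again a limit rather than a number. The step that the two limits leave unreadable from compound 1 to compound 2 therefore cannot be sized, because both values sit at the limit of > 100000 nM in this assay, at which 2 of the 2 values shown sit.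

Compound 3 `Cc1cccn2c(-c3ccc(O)cc3)c(N)nc12` differs from compound 1 by methyl in place of hydrogen on an aromatic carbon. Among the measured compounds shown here, the only measured step that bears on it, from compound 1 to compound 2, is the unreadable one just described, so there is no sized precedent for a substituent entering the shared core. With compound 1 already at a limit, compound 3 is expected to remain near that limit as well, and the expected step that the limit leaves unreadable from compound 1 to compound 3 is essentially none that could be read. Compound 3 is estimated at 150000 nM, with a range from 50000 nM to 400000 nM, and the assay is expected most likely to report only a limit for it.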

Compound 3, half-maximal inhibitory concentration: > 100000 nM
Compound 3 was reported as a limit; the forecaster's own chance of this, stated with the estimate: 80%; the middle value is on the limit's open side.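

The step from compound 1 to compound 3 cannot be read, because both values are limits of the assay and not numbers: the limit of > 100000 nM in this assay, at which 3 of the 3 values shown sit.

The compounds shown leave open whether any substituent on the shared core can bring a compound into the range where this assay gives a number.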